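The source may hold more compounds than are shown below. What is called first, only, known or untested is meant among the compounds shown, and "the series" means these compounds.

Of the compounds shown here, two sharing one core have been tested in a functional assay on COLO 205 cells (Homo sapiens) for antiproliferative activity, read by sulforhodamine B assay, with a stated time of 72 h; a lower number here means a stronger inhibitor, a higher number a weaker inhibitor. Compound 1, `NC(=S)NNc1nncc2ccccc12`, gives 55 nM in this assay. Compound 2, `O=S(=O)(Nc1ccccn1)c1ccc(Nc2nncc3ccccc23)cc1`, gives 44 nM in this assay. Of the two numbers, compound 2 shows the lower one, but the gap to compound 1 is within the usual scatter of repeated measurements, so the two cannot be told apart on these data.

Compound 3, `O=S(=O)(Nc1nccs1)c1ccc(Nc2nncc3ccccc23)cc1`, has not yet been measured. It differs from compound 2 in one place: 1,3-thiazol-2-yl in place of pyridin-2-yl on a sulfonamide nitrogen. For the measured compounds named here, no measured pair in this set shows this change, so its effect is unknown here; the sulfonamide nitrogen keeps its sulfonyl sulfur neighbour, and only the ring on that nitrogen is swapped.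

With nothing in the data pointing in either direction, the expected step is a 1.1-fold higher number from compound 2 to compound 3 (0.06 log units; within the scatter), no larger than the scatter. Compound 3 is therefore expected to give 50 nM in this assay, within a range from 20 nM to 130 nM.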

Compound 3, half-maximal inhibitory concentration: 56 nM
Compound 3: middle estimate off by 1.1-fold (0.05 log units), on the low side; low and high end bracket the measured number.
By their numbers in this assay, from the lowest: compounds 2, 1 and 3 (each within the scatter of the next).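

In this assay the exchange of pyridin-2-yl for 1,3-thiazol-2-yl on the sulfonamide nitrogen gives a 1.3-fold higher number from compound 2 to compound 3 (0.10 log units; within the scatter) and so compound 2 and compound 3 cannot be told apart. For the compounds shown here, this is the first measured change at this position, and it shows that a five-membered aromatic ring with 2 hetero atoms can stand in place of a six-membered aromatic ring with 1 hetero atom without a difference that can be read in these numbers. No measurement at hand bears on how this ring exchange acts on the cells.

As far as these compounds go, both rings tested here are aromatic and carry a ring nitrogen, so it remains open whether the number would hold with a plain phenyl ring, a methyl group or a longer alkyl chain on that sulfonamide nitrogen. From the compounds shown here alone, it also remains open how a carboxylic acid or a primary amine in place of the whole sulfonamide would read in this assay and whether the sulfonamide matters at all.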